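Changing the Chain on the Amide Carbonyl

A few compounds are considered here, and "the series" means these few. Any claim that something is new, unique, unknown or untested is made for them only; others in the source may bear on it.

Measured compounds:
Compound 1, `COc1ccc(CN(C(=O)CCCl)c2cc(OC)c(OC)c(OC)c2)cc1O`: 110 nM
Compound 2, `COc1ccc(N(Cc2cc(OC)c(OC)c(OC)c2)C(=O)CCl)cc1O`: 29800 nM

Compound 1 and compound 2 carry the same two substituted rings, but attach them to the amide nitrogen the other way round, and they also differ in the chain on the carbonyl. In a functional assay on KYSE-450 cells (Homo sapiens) for inhibition, read by MTT assay, with a stated time of 48 h (on this read-out higher numbers stand for weaker inhibition and lower numbers for stronger inhibition), compound 1 gives 110 nM, the lowest of the two numbers. Compound 2 gives 29800 nM, a gap that lies far beyond the scatter of repeated measurement. Among the compounds with values here, no pair of measured compounds differs in only one place, so this large gap is the only measured comparison in hand.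

Compound 3, `COc1ccc(CN(C(=O)/C=C/CBr)c2cc(OC)c(OC)c(OC)c2)cc1O`, keeps the arrangement of compound 1 and alters only the chain on the carbonyl: 3-bromoprop-1-en-1-yl in place of 2-chloroethyl on a carbonyl carbon. Nothing measured here shows what such a swap does on its own. Because compound 1 stands at 110 nM, compound 3 is expected to stay near that mark, within the usual scatter or a little stronger. The expected step of a 1.6-fold lower number from compound 1 to compound 3 (0.20 log units; within the scatter) is therefore estimated to be small. Compound 3 is expected to give 70 nM, with a range from 15 nM to 400 nM.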

Compound 3, half-maximal inhibitory concentration: 100 nM
Beside the measured number, compound 3's estimate is 1.4-fold (0.15 log units) below it, and the stated range covers the measured number.
By their numbers in this assay, from the lowest: compounds 3 and 1 (each within the scatter of the next); then compound 2.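

In this assay, within the data shown here, the swap of chains on the carbonyl gives a 1.1-fold lower number from compound 1 to compound 3 (0.04 log units; within the scatter) and is the first comparison here in which only one place differs, so it can be read on its own. At this position, 3-bromoprop-1-en-1-yl and 2-chloroethyl read alike, even though the first carries a double bond and bromine where the second has a saturated chain and chlorine, so the activity of compound 1 does not depend on the exact 2-chloroethyl chain. Nothing measured here offers an explanation for why these two chains give matching numbers.

The compounds shown do not say whether a halogen on this chain matters at all, since each chain here carries one, and a plain propyl chain or a chain ending in an amine would put that question to the test. They also leave the large gap to compound 2 unresolved, as that compound differs from compound 1 both in the chain on the carbonyl and in how the two rings sit on the amide nitrogen, and the share of each difference cannot be separated.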